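The compounds below may be only part of what the source reports. "The series", "measured", "known", "first", "only" and "open" are said of these compounds alone.

In a functional assay on the whole organism for inhibition, with Felis catus as the target, with a stated time of 30 min (a higher number here means that more compound is needed for the effect, a lower number that less compound is needed), the three measured compounds lie close together: compound 1 `OC(CNCCOc1ccc(Cl)cc1)COc1ccccc1` gives 0.08 mg/kg, compound 2 `OC(CNCCOc1ccccc1F)COc1ccccc1` gives 0.081 mg/kg and compound 3 `COCCNCC(O)COc1ccccc1` gives 0.13 mg/kg. Compound 3 therefore stands within the scatter of both other compounds. Compound 4 `CCOCCNCC(O)COc1ccccc1` differs from compound 3 by one change: methyl in place of hydrogen on a saturated chain carbon bound to an oxygen on a saturated carbon. In words, this is methyl in place of hydrogen on a saturated chain carbon bound to an oxygen on a saturated carbon, turning methoxy into ethoxy.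

The measured steps that bear on it are changes of the group on that same oxygen. These are a 1.6-fold higher number from compound 1 to compound 3 (0.21 log units; within the scatter) and a 1.6-fold higher number from compound 2 to compound 3 (0.21 log units; within the scatter), together with a 1.0-fold higher number from compound 1 to compound 2 (0.01 log units; within the scatter). None of them leaves the scatter, even with 4-chlorophenyl, 2-fluorophenyl and methyl exchanged there. No step beyond the scatter is therefore expected in this assay from this smaller change, and no direction can be assigned to it. The expected size is a 1.3-fold lower number from compound 3 to compound 4 (0.11 log units; within the scatter). For compound 4 the estimate is 0.1 mg/kg, with an expected range of 0.05 mg/kg to 0.22 mg/kg.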

Compound 4, dose for half-maximal effect: 0.047 mg/kg
Estimate against measurement, compound 4: 2.1-fold (0.33 log units) above; measured number outside the range, below it.
By their numbers in this assay, from the lowest: compounds 4, 1, 2 and 3 (each within the scatter of the next, the first and the last beyond it).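

In this assay, for the compounds shown here, methyl in place of hydrogen on a saturated chain carbon bound to an oxygen on a saturated carbon gives a 2.8-fold lower number from compound 3 to compound 4 (0.44 log units; beyond the scatter), the only step so far that lies beyond the scatter, so this position responds to the addition of a single carbon even though the earlier exchanges on the oxygen stayed within it. Ethyl on that oxygen cannot be told apart from the two aryl groups, with a 1.7-fold lower number from compound 2 to compound 4 (0.24 log units; within the scatter) and a 1.7-fold lower number from compound 1 to compound 4 (0.23 log units; within the scatter), and only the pair of methyl and ethyl separates. Nothing measured here gives a cause for this step.

From the compounds shown here alone, whether the trend from methoxy to ethoxy continues with a longer chain on that oxygen, such as propyl or butyl, remains open. Also open, going by these compounds, is how a branched group such as isopropyl, or an amine at the end of the chain, would compare with ethyl.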